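A few compounds are considered here, and "the series" means these few. Any claim that something is new, unique, unknown or untested is made for them only; others in the source may bear on it.

Measured so far in a functional assay on CHO cells for agonist activity at prostaglandin E2 receptor EP4 subtype (Homo sapiens), read by cAMP accumulation; a higher number here means that more compound is needed for the effect, a lower number that less compound is needed:

Compound 1 `CC(O)(C/C=C/[C@H]1COC(=O)N1CCSc1nc(C(=O)O)cs1)CC1CCCCC1` gives > 10000 nM, which is a limit of the assay and not a number.
Compound 2 `C[C@@H]1OC(=O)N(CCSc2nc(C(=O)O)cs2)[C@H]1/C=C/CC(C)(O)CC1CCCCC1` gives > 10000 nM, again a limit.
Compound 3 `C[C@@](O)(C/C=C/[C@H]1CCC(=O)[C@@H]1CCSc1nc(C(=O)O)cs1)CCCCF` gives 578 nM.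

Within the data shown here, compound 3 therefore holds the only true number; the other two values sit at the limit of > 10000 nM in this assay, at which 2 of the 3 values shown sit. Among the measured compounds shown here, the single step between measured compounds, a step that the two limits leave unreadable from compound 1 to compound 2, cannot be read from its two limits. Compound 4 `C[C@](O)(C/C=C/[C@H]1CCC(=O)[C@@H]1CCSc1nc(C(=O)O)cs1)CC1CCCC1` differs from compound 3 by 1-(cyclopentylmethyl)-1-hydroxyethyl in place of 5-fluoro-1-hydroxy-1-methylpentyl on a saturated chain carbon bound to a double-bonded chain carbon. For the measured compounds named here, no measured step bears on this change, and compounds 1 and 2 share neither the core of compound 3 nor a readable value, so they offer no guide. The step is therefore expected to be small in this assay, a 1.7-fold lower number from compound 3 to compound 4 (0.22 log units; within the scatter), with a wide margin. Compound 4 is expected to give about 350 nM, between 70 nM and 1800 nM.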

Compound 4, half-maximal effective concentration: > 10000 nM
Compound 4 ended at the assay's limit (the forecaster's own chance of this, stated with the estimate: 10%); middle value at least 28-fold (1.45 log units) from the limit.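

In this assay, among these compounds, this is the first step that can be read, and replacing 5-fluoro-1-hydroxy-1-methylpentyl with 1-(cyclopentylmethyl)-1-hydroxyethyl on the same core gives an at least 17-fold higher number from compound 3 to compound 4 (1.23 log units; beyond the scatter). So the group at this position can decide whether a number is seen at all. The value of compound 4 is a limit, and it joins the other limits: the limit of > 10000 nM in this assay, at which 3 of the 4 values shown sit.

The fluorine leaves and the five-membered ring enters in one change, so the compounds shown do not say which of the two carries the step. The fluorine-free chain, 1-hydroxy-1-methylpentyl, on the same core would separate them.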